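This account rests on a few compounds, and the source may have more. Where it says the series, first, only, none or still open, it means among the compounds named here.

This small set of compounds was examined in an ADME assay on Vero cells (Chlorocebus sabaeus) for cytotoxicity, read by microscopy, with a stated time of 6 days; a lower number here means that less compound is tolerated, a higher number that more compound is tolerated. Compound 1 `CCCCCCCNc1cnc(C(=O)NCc2ccccc2)cn1` carries a seven-carbon chain on its amine, compound 3 `CCCCNc1nccnc1C(=O)NCc1ccccc1` carries a butylamino group on the shared core, compound 2 `O=C(NCc1ccccc1)c1cncc(Cl)n1` carries a chloro group in place of any amine, and compound 4 `CCCCNc1cncc(C(=O)NCc2ccccc2)n1` has yet to be tested.

For compound 1 this assay gives only a limit, >= 100000 nM. For compound 3 this assay likewise gives only a limit, > 100000 nM. For compound 2 the result in this assay is "not determined" (no result reported), so no number places it among the others. The two further values shown in this assay are limits, summarised in the limit of > 100000 nM in this assay, at which 1 of the 3 values shown sits, and (the limit of >= 100000 nM in this assay, at which 1 of the 3 values shown sits).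

The move from compound 2 to compound 4 is butylamino in place of chloro on an aromatic carbon. Among the measured compounds shown here, no measured pair in this set differs by exactly this change, so no step size can be read off. Both compounds that carry an alkylamino group on the core, compound 1 and compound 3, sit at a limit in this assay, and compound 4 is a close relative of compound 3. Compound 4 is therefore expected to be tolerated up to the limit of this assay as well, with an estimated minimum cytotoxic concentration of 100000 nM, lying between 50000 nM and 200000 nM.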

Compound 4, minimum cytotoxic concentration: 100000 nM
Compound 4: the middle estimate sits on the measured number at the digits printed; the range from low to high includes it.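

Among the compounds shown here, compound 2 carries no number in this assay, so the swap of chloro for butylamino that leads to compound 4 gives no step that can be read. The compounds shown leave open what this swap does to tolerance by the cells, and how compound 4 compares with compound 1 and compound 3, which give only limits.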